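The source may report more compounds than this note shows. Statements on the series, on what has been measured and on what is new or still open speak of the compounds shown alone.

Working notes on the series. Compound 1 `O=C(Nc1ccc(Oc2ccnc3[nH]ccc23)cc1)c1cc(-c2ccccc2)ncn1` and compound 2 `Cc1ccc(-c2ccnc(C(=O)Nc3ccc(Oc4ccnc5[nH]ccc45)c(F)c3)n2)cc1` share a core and have been measured in a functional assay on HepG2 cells (Homo sapiens) for cytotoxicity, read by MTT assay, with a stated time of 72 h; a lower number here means a stronger inhibitor, a higher number a weaker inhibitor. In this assay compound 1 gives 3110 nM. In this assay, for the measured compounds named here, compound 2 gives 16400 nM, the highest of the two numbers so far; the nearest number is that of compound 1, whose value is lower by an amount beyond the usual scatter. Going by the values given here, compound 1 and compound 2 differ in more than one place, so their two values show only that compound 2 is the weaker inhibitor of the pair, and nothing is attributed to any single change.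

Compound 3 `O=C(Nc1ccc(Oc2ccnc3[nH]ccc23)c(F)c1)c1nccc(-c2cccc(Cl)c2)n1` is the next entry and is not yet measured. It differs from compound 2 in one place: 3-chlorophenyl in place of 4-methylphenyl on an aromatic carbon. Nothing measured in the series bears on this particular change, so no direction beyond the scatter can be given for it. The expected step is a 1.4-fold lower number from compound 2 to compound 3 (0.14 log units; within the scatter), that is, none that clearly exceeds the scatter. The estimate for compound 3 in this assay is 12000 nM, expected to fall between 4000 nM and 35000 nM.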

Compound 3, half-maximal inhibitory concentration: 9340 nM
The estimate for compound 3 lay 1.3-fold (0.11 log units) above the measured number; the measured number falls inside the stated range.
By their numbers in this assay, from the lowest: compound 1; then compounds 3 and 2 (each within the scatter of the next).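

For the compounds shown here, the exchange of 4-methylphenyl for 3-chlorophenyl on the aromatic carbon next to the ring nitrogen gives the first single-place step: in this assay it is a 1.8-fold lower number from compound 2 to compound 3 (0.24 log units; within the scatter) for this change. At this position, therefore, the two substituted phenyl groups cannot be told apart in this assay, and this one exchange gives no handle on the number. No measurement in hand offers an explanation for this result.

The step changes both the substituent on the phenyl ring and its place on that ring, so the compounds shown cannot separate the effect of methyl versus chlorine from that of the 3- versus the 4-position; 3-methylphenyl and 4-chlorophenyl at the same carbon would divide the two. Going by these compounds, it also remains open whether a group of a different kind there, such as an amine, a carboxylic acid or a longer chain, would shift the number beyond the scatter, since both compounds in this step carry a substituted phenyl at that carbon.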